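A few compounds are considered here, and "the series" means these few. Any claim that something is new, unique, unknown or untested is made for them only; others in the source may bear on it.

Measured in an ADME assay on HEK293 cells (Homo sapiens) for inhibition, read by MTT assay, with a stated time of 2 days; a lower number here means a stronger inhibitor, a higher number a weaker inhibitor:
compound 1, `COc1ccccc1/C=C/c1cccc(O)c1`: 24 ug/mL
compound 2, `COc1ccccc1/C=C/c1ccc(O)cc1`: 41 ug/mL
compound 3, `COc1ccccc1/C=C/c1cccc(N)c1`: 45 ug/mL

Compound 1 and compound 3 share a core and differ in one place: amino in place of hydroxy on an aromatic carbon. The step this makes in this assay is a 1.9-fold higher number from compound 1 to compound 3 (0.27 log units; within the scatter), so within the scatter of the method, nothing more can be read from it than that the two numbers lie close together.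

Compound 2 is built from the same atoms as compound 1, joined differently; the difference between the two cores is not broken down here. Compound 2 and compound 3 give numbers within the scatter of each other in this assay.

Compound 4, `COc1ccccc1/C=C/c1ccc(N)cc1`, has not been measured. It differs from compound 2 in one place: amino in place of hydroxy on an aromatic carbon. For the measured compounds named here, this is the same kind of change as the one from compound 1 to compound 3, but not the same: there the place is meta to a large group, here it is para to a large group. Going by the values given here, only one earlier instance of the change exists, and it sits within the scatter, so the expectation for compound 4 rests on that single step alone.

The step from compound 2 to compound 4 in this assay is expected to be about a 1.7-fold higher number from compound 2 to compound 4 (0.23 log units; within the scatter), guided by a 1.9-fold higher number from compound 1 to compound 3 (0.27 log units; within the scatter). Compound 4 is thus estimated at 70 ug/mL, with a range from 35 ug/mL to 140 ug/mL.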

Compound 4, half-maximal inhibitory concentration: 1 ug/mL
Compound 4: the middle estimate sits 70-fold (1.85 log units) above what was measured; measured number below the stated range.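

In this assay, amino in place of hydroxy on an aromatic carbon, para to a large group, gives a 41-fold lower number from compound 2 to compound 4 (1.61 log units; beyond the scatter), a large step. For the compounds shown here, the change therefore does not carry as a fixed step from one core to the other, and a step read on the core of compound 1 is a poor guide to the same change on the core of compound 2: the same change on two cores in this assay, a 1.9-fold higher number (0.27 log units; within the scatter) from compound 1 to compound 3 and a 41-fold lower number (1.61 log units; beyond the scatter) from compound 2 to compound 4, 77-fold (1.89 log units) apart, beyond the scatter of two such steps What this does not show is which difference between the two cores sets the size of the step, or why the step is so large, since each core supplies only a single pair and the place of the change is not the same on both.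

Still open, as far as these compounds go, is whether the large step belongs to amino itself or would also appear with a methylamino group, a dimethylamino group or an acetamide at the same place, para to a large group. Also open is whether the step depends on the methoxy group of the shared core, which stays unchanged across all the compounds shown, and whether it would survive with a fluorine or a longer alkoxy chain there.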